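Working notes: changing the group on the carbonyl carbon

The source may hold more compounds than are shown below. What is called first, only, known or untested is meant among the compounds shown, and "the series" means these compounds.

- compound 1 `CCn1c(C(=O)NCCN(C)C)ccc1C(CC)(CC)c1ccc(OCC(O)C(C)(C)C)c(C)c1` gives 870 nM
- compound 2 `CCn1c(C(=O)N(CCC#N)CCC#N)ccc1C(CC)(CC)c1ccc(OCC(O)C(C)(C)C)c(C)c1` gives 42000 nM

In a functional assay on HepG2 cells (Homo sapiens), read by MTT assay, with a stated time of 48 h (on this read-out higher numbers stand for weaker inhibition and lower numbers for stronger inhibition), compound 2 holds the higher of the two numbers. Compound 3 `CCn1c(C(=O)Oc2ccc(CCO)cc2)ccc1C(CC)(CC)c1ccc(OCC(O)C(C)(C)C)c(C)c1` differs from compound 2 by a group of 10 heavy atoms (8 carbon, 2 oxygen; one six-membered aromatic ring of carbon only) in place of a group of 9 heavy atoms (6 carbon, 3 nitrogen; no ring), on a carbonyl carbon. Among the compounds with values here, the only measured step, a 48-fold higher number from compound 1 to compound 2 (1.68 log units; beyond the scatter), also changes the group on this carbonyl carbon, so the read-out clearly responds to that group. With one step, the direction for the new group remains uncertain. A moderate move to a lower number is expected, smaller than that step. The expected change is a 7.0-fold lower number from compound 2 to compound 3 (0.85 log units; beyond the scatter). The estimate for compound 3 is 6000 nM, with an expected range from 1000 nM to 35000 nM.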

Compound 3, half-maximal inhibitory concentration: > 50000 nM
Compound 3 ended at the assay's limit; the forecaster's own chance of this, stated with the estimate: 15%; middle value at least 8.3-fold (0.92 log units) away from the limit.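

Compound 3 is a limit and not a number: the limit of > 50000 nM in this assay, at which 1 of the 3 values shown sits. With a carbon-only aromatic ring and a hydroxyl-bearing chain in the group on this carbonyl carbon, the number stays far from that of compound 1, with an at least 57-fold higher number from compound 1 to compound 3 (1.75 log units; beyond the scatter). The comparison with the nitrile-bearing group gives an at least 1.1-fold higher number from compound 2 to compound 3 (0.07 log units; that floor lies within the scatter), so no order between these two compounds can be stated.

The compounds shown leave open whether a carboxylic acid or a primary amine on a longer chain at this carbonyl carbon would give a number nearer that of compound 1.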